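The compounds below may be only part of what the source reports. "The series", "measured", "known", "first", "only" and "open" are said of these compounds alone.

Measured so far in an ADME assay on BHK-21 cells (Mesocricetus auratus) for cytotoxicity, with a stated time of 3 days; on this read-out higher numbers stand for lower toxicity in this test and lower numbers for higher toxicity in this test:
compound 1, `O=C(CCSc1nnc(-c2ccncc2)s1)Nc1ccc(Cl)cc1`, 8210 nM;
compound 2, `O=C(CCSc1nnc(-c2ccncc2)s1)Nc1ccc(Cl)cc1Cl`, with a value that is a limit of this assay, > 50000 nM;
compound 3, `O=C(CCSc1nnc(-c2ccncc2)s1)NCc1ccccc1`, 18700 nM.

Compound 3 holds the highest of the two numbers given; its nearest neighbour is compound 1, with a 2.3-fold higher number from compound 1 to compound 3 (0.36 log units; beyond the scatter). Compound 4, `O=C(CCSc1nnc(-c2ccncc2)s1)NCc1ccc(Cl)cc1`, differs from compound 3 by chloro in place of hydrogen on an aromatic carbon. Within the data shown here, the one measured step of the same kind is an at least 6.0-fold higher number from compound 1 to compound 2 (0.78 log units; beyond the scatter), which reached only (the limit of > 50000 nM in this assay, at which 1 of the 3 values shown sits); the step of an at least 2.6-fold lower number from compound 2 to compound 3 (0.42 log units; beyond the scatter) also involves a chloro-bearing compound but changes the nitrogen substituent as a whole. On this basis a small rise is expected for compound 4, a 1.5-fold higher number from compound 3 to compound 4 (0.18 log units; within the scatter). Compound 4 is therefore estimated at 28000 nM, between 12000 nM and 60000 nM.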

Compound 4, half-maximal cytotoxic concentration: 21500 nM
The estimate for compound 4 lay 1.3-fold (0.11 log units) above the measured number; measured number inside the range.
By their numbers in this assay, from the lowest: compound 1; then compounds 3 and 4 (each within the scatter of the next). At a limit, above all of these: compound 2.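

In this assay, chloro in place of hydrogen on the benzyl group gives a 1.1-fold higher number from compound 3 to compound 4 (0.06 log units; within the scatter), so the same change does not read alike on the two nitrogen substituents: the same change on two cores in this assay, an at least 6.0-fold higher number (0.78 log units; beyond the scatter) from compound 1 to compound 2 and a 1.1-fold higher number (0.06 log units; within the scatter) from compound 3 to compound 4, at least 5.2-fold (0.72 log units) apart, beyond the scatter of two such steps. With chloro held in place, the 4-chlorobenzyl group gives a 2.6-fold higher number from compound 1 to compound 4 (0.42 log units; beyond the scatter) relative to the 4-chlorophenyl group. Against the 2,4-dichlorophenyl group the step is an at least 2.3-fold lower number from compound 2 to compound 4 (0.36 log units; beyond the scatter), but compound 2 stands only at a limit: the limit of > 50000 nM in this assay, at which 1 of the 4 values shown sits.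

Still open, going by these compounds, is whether a 2,4-dichlorobenzyl group would read like compound 2 or like compound 4. Also open, on these data alone, is how an amine or a carboxylic acid on that aromatic ring, or a longer chain in place of benzyl, would read in this assay.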